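Phenyl to Prop-1-en-1-yl on the Ester Carbonyl

The source may report more compounds than this note shows. Statements on the series, on what has been measured and on what is new or still open speak of the compounds shown alone.

Of the compounds shown here, three sharing one core have been tested in an ADME assay on HepG2 2.2.15 cells (Homo sapiens) for cytotoxicity; a higher number here means that more compound is tolerated, a lower number that less compound is tolerated. Compound 1 `Cn1c(=O)c(CCO)c(-c2ccccc2Cl)c2cc(Cl)ccc21` gives 34000 nM, compound 2 `O=c1c(CCO)c(-c2ccccc2Cl)c2cc(Cl)ccc2n1-c1ccccc1` gives 26000 nM, and compound 3 `O=C(OCCc1c(-c2ccccc2Cl)c2cc(Cl)ccc2[nH]c1=O)c1ccccc1` gives 43000 nM. Compound 3 sits alongside the other two: its gaps to compound 1 and to compound 2 both lie within the scatter, so no ordering can be read from them. Compound 4 `C/C=C/C(=O)OCCc1c(-c2ccccc2Cl)c2cc(Cl)ccc2[nH]c1=O` differs from compound 3 in one place: prop-1-en-1-yl in place of phenyl on a carbonyl carbon. Within the data shown here, the only measured step, a 1.3-fold lower number from compound 1 to compound 2 (0.12 log units; within the scatter), changes a different part of the molecule and stays within the scatter, so nothing on record speaks to an ester change. For compound 4 the expected step is therefore a 1.1-fold lower number from compound 3 to compound 4 (0.03 log units; within the scatter), with an estimated value of 40000 nM in the range 18000 nM to 90000 nM in this assay.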

Compound 4, half-maximal cytotoxic concentration: 30000 nM
The estimate for compound 4 lay 1.3-fold (0.12 log units) above the measured number; low and high end bracket the measured number.
By their numbers in this assay, from the lowest: compounds 2, 4, 1 and 3 (each within the scatter of the next).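

In this assay, putting prop-1-en-1-yl in place of phenyl on a carbonyl carbon gives a 1.4-fold lower number from compound 3 to compound 4 (0.16 log units; within the scatter). Among these compounds, this is the first measured step at this position, and it shows that an open chain with one double bond can replace the aromatic ring without a readable shift in tolerated concentration. No supporting measurement is available to explain this result. Still open, going by these compounds, is whether a group carrying an amine or a carboxylic acid, or a longer chain, on this carbonyl carbon would also stay within the scatter of compound 3.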